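The compounds below may be only part of what the source reports. "The series", "measured", "known", "first", "only" and "open" are said of these compounds alone.

Of the compounds shown here, two have been measured so far. Compound 1 `O=C(Nc1ccc(Cl)cc1)c1cn(-c2ccccc2)nc1-c1ccccc1` in a functional assay on HCT-116 cells (Homo sapiens) for cytotoxicity, read by MTT assay, with a stated time of 48 h (a higher number here means a weaker inhibitor, a lower number a stronger inhibitor), gives 3520 nM. Compound 2 `Cc1ccc(-c2nn(-c3ccccc3)cc2C(=O)Nc2ccccc2)cc1` in this assay gives 2360 nM. Of these two numbers, compound 2 carries the lower one, but the gap between compound 2 and compound 1 lies within the scatter of repeated measurements, so the two cannot be told apart on these figures.

Compound 3 `CCOc1ccc(NC(=O)c2cn(-c3ccccc3)nc2-c2ccc(C)cc2)cc1` has not yet been measured. It differs from compound 2 in one place: ethoxy in place of hydrogen on an aromatic carbon. The group enters on an aromatic carbon of a six-membered aromatic ring of carbon only, para to a large group; put another way, the phenyl on the amide nitrogen becomes a 4-ethoxyphenyl.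

No measured pair shows what such an ethoxy does here, so there is no shown step to lean on. The expectation for compound 3 is therefore a small step from compound 2, a 1.2-fold lower number from compound 2 to compound 3 (0.07 log units; within the scatter), most likely not beyond the scatter, with a slight lean toward a lower number. Compound 3 is estimated at 2000 nM, within a range from 900 nM to 4500 nM.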

Compound 3, half-maximal inhibitory concentration: 780 nM
Compound 3: the middle estimate sits 2.6-fold (0.41 log units) above what was measured, outside the stated range (below it).
By their numbers in this assay, from the lowest: compound 3; then compounds 2 and 1 (each within the scatter of the next).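

In this assay, among these compounds, turning the phenyl into 4-ethoxyphenyl gives a 3.0-fold lower number from compound 2 to compound 3 (0.48 log units; beyond the scatter) and this modest step is the first one that lies beyond the scatter. It shows that this aromatic carbon, para to a large group, accepts ethoxy in place of hydrogen and that the cell read-out responds to the change, here toward a stronger inhibitor. The earlier compounds could not show this: compound 1 and compound 2 differ in more than one place and their numbers lie within the scatter of each other, while no measurement at hand explains why ethoxy has this effect.

A single step cannot say whether ethoxy itself matters or whether another group here, such as methoxy, a longer chain like butoxy, a hydroxyl or an amine, would do the same, better or worse. It also leaves open whether ethoxy would act the same way at another place on this ring, or in a compound that keeps the rest of compound 1 rather than that of compound 2.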